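The source may hold more compounds than are shown below. What is called first, only, known or untested is meant among the compounds shown, and "the series" means these compounds.

Measured compounds:
- compound 1, `O=C(NCc1cc(Cl)ccc1-n1cnnn1)[C@@H]1C[C@@H]2C[C@@H]2N1C(=O)[C@H](O)Cc1ccccn1`: 1.2 10^-6 cm/s
- compound 2, `O=C(NCc1cc(Cl)ccc1-n1cnnn1)[C@@H]1C[C@@H]2C[C@@H]2N1C(=O)[C@H](O)c1ccccc1F`: 16 10^-6 cm/s
- compound 3, `CCCC[C@@H](O)C(=O)N1C[C@H]2C[C@H]2[C@H]1C(=O)NCc1cc(Cl)ccc1-n1cnnn1`: 33 10^-6 cm/s

In an ADME assay on Caco-2 cells (Homo sapiens) for permeability, read by LC-MS, in the apical to basolateral direction, with a stated time of 60 min, at pH 6.5 (on this read-out lower numbers stand for lower permeability and higher numbers for higher permeability), compound 2 stands second highest of the three numbers. Compound 3 gives the highest number, 33 10^-6 cm/s, and compound 1 the lowest, 1.2 10^-6 cm/s, so compound 2 sits nearer to compound 3 than to compound 1.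

The next compound, compound 4, `O=C(NCc1cc(Cl)ccc1-n1cnnn1)[C@@H]1C[C@@H]2C[C@@H]2N1C(=O)[C@H](O)c1ccccc1`, differs from compound 2 in one place: hydrogen in place of fluoro on an aromatic carbon.

Among the compounds with values here, only one measured step is known, a 13-fold higher number from compound 1 to compound 2 (1.12 log units; beyond the scatter), and that step swapped a whole (pyridin-2-yl)methyl group for a 2-fluorophenyl group. Within the data shown here, no measured pair differs by a fluoro alone, so there is no direct guide for the change from compound 2 to compound 4. A single fluorine atom is a small change beside the one that was measured, and the step to compound 4 is therefore expected to be small, probably within the scatter, in either direction: a 1.2-fold lower number from compound 2 to compound 4 (0.09 log units; within the scatter).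

Compound 4 is expected to give about 13 10^-6 cm/s in this assay, most likely between 6 10^-6 cm/s and 26 10^-6 cm/s.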

Compound 4, apparent permeability: 8 10^-6 cm/s
Estimate against measurement, compound 4: 1.6-fold (0.21 log units) above, within the range that was stated.
By their numbers in this assay, from the lowest: compound 1; then compounds 4 and 2 (each within the scatter of the next); then compound 3.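

Hydrogen in place of fluoro on this aromatic carbon, ortho to a large group, gives a 2.0-fold lower number from compound 2 to compound 4 (0.30 log units; within the scatter) in this assay, so this read-out does not separate compound 2 from compound 4. With phenyl in place of (pyridin-2-yl)methyl, the comparison gives a 6.7-fold higher number from compound 1 to compound 4 (0.82 log units; beyond the scatter), which is beyond the scatter, as is a 13-fold higher number from compound 1 to compound 2 (1.12 log units; beyond the scatter), so the gap from compound 1 does not depend on the fluoro being present. No measurement shown here explains these numbers.

On these data alone, a chlorine, an amine or a carboxylic acid at this aromatic position remains open. Also open, as far as these compounds go, is how a pyridin-2-yl group set directly on the saturated chain carbon would read, as compound 1 differs from compound 4 in both the ring and the link that carries it.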